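The source may report more compounds than this note shows. Statements on the series, on what has been measured and on what is new or still open speak of the compounds shown alone.

Compound 1 `Cc1ccc(CS(=O)(=O)/C(=C/c2c[nH]c3ccccc23)C(=O)c2ccc(Cl)cc2)cc1` was tested in a functional assay on DU-145 cells (Homo sapiens) for inhibition, read by trypan blue exclusion, with a stated time of 96 h (a lower number here means a stronger inhibitor of growth, a higher number a weaker inhibitor of growth), where compound 1 gives 25000 nM. Compound 3 `COc1cc(OC)c(/C=C(\C(=O)c2ccc(Cl)cc2)S(=O)(=O)c2ccc(C)cc2)c(OC)c1` gives 25000 nM in this assay, no change from compound 1 at the digits shown and within the scatter, while compound 2 `O=C(/C(=C\c1ccc(OCc2ccccc2)cc1)SCc1ccc(Cl)cc1)c1ccc(Cl)cc1` gives 1000 nM, the lowest of the three numbers, so compound 1 stands level with compound 3 at the high end of what has been measured. Compound 4 `Cc1ccc(CS(=O)(=O)/C(=C/c2ccccc2Br)C(=O)c2ccc(Cl)cc2)cc1` is not yet measured and differs from compound 1 by 2-bromophenyl in place of 1H-indol-3-yl on a double-bonded chain carbon bound to a double-bonded chain carbon. Going by the values given here, no measured pair shows this change directly. Because compound 1 gives 25000 nM and compound 3 gives 25000 nM with a different group at that place, the step of a 1.3-fold lower number from compound 1 to compound 4 (0.10 log units; within the scatter) is expected to stay within the scatter. Compound 4 is therefore estimated at 20000 nM, with a range from 5000 nM to 50000 nM.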

Compound 4, concentration for 50% growth inhibition: 25000 nM
Beside the measured number, compound 4's estimate is 1.3-fold (0.10 log units) below it; the range from low to high includes it.
By their numbers in this assay, from the lowest: compound 2; then compounds 1, 3 and 4 (each within the scatter of the next).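

In this assay, going by these compounds alone, putting 2-bromophenyl in place of 1H-indol-3-yl on a double-bonded chain carbon bound to a double-bonded chain carbon gives no change at the digits printed from compound 1 to compound 4 (within the scatter) and is the first direct reading of a change at this place. It shows that, on the core of compound 1, the number holds without the 1H-indol-3-yl group and its hydrogen-bond donor. No measurement shown here accounts for this result. From the compounds shown here alone, whether an amine or a carboxylic acid at this place would move the number remains open.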